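The source may hold more compounds than are shown below. What is called first, only, known or untested is meant among the compounds shown, and "the series" means these compounds.

Measured so far in an assay on HEK293 cells for displacement of a labelled ligand from 5-hydroxytryptamine receptor 7 (Rattus norvegicus), read by radioligand binding; a lower number here means a stronger inhibitor, a higher number a weaker inhibitor:

Compound 1 `CCn1nc2c(c1-c1ccccc1)CCNCC2` gives 140 nM.
Compound 2 `c1ccc(-c2c3c(nn2C2CCC2)CCNCC3)cc1` gives 90 nM.
Compound 3 `Cc1ccc(-c2c3c(nn2C(C)C)CCNCC3)cc1` gives 6 nM.

Compound 3 has the lowest number of the three, and its gaps to compound 2 and to compound 1 both lie beyond the usual scatter, so it is the strongest inhibitor of this set. Compound 4 `CC(C)n1nc2c(c1-c1ccc(C#N)cc1)CCNCC2` shares the core of compound 3 and differs from it only at one point: cyano in place of methyl on an aromatic carbon.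

For the measured compounds named here, the one single-point step measured so far, a 1.6-fold lower number from compound 1 to compound 2 (0.19 log units; within the scatter), concerns a change on the nitrogen of the core and lay within the scatter, so it does not bear on a change on the carbon ring. The gap between compound 2 and compound 3 combines two changes and cannot be split. Going by the values given here, there is therefore no direct precedent for this step, and the expectation for compound 4 rests on compound 3 alone, with a wide range. The step from compound 3 to compound 4 is estimated as a 2.5-fold higher number from compound 3 to compound 4 (0.40 log units; beyond the scatter). For compound 4 the expected value in this assay is 15 nM, between 4 nM and 60 nM.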

Compound 4, inhibition constant: 90 nM
The estimate for compound 4 lay 6.0-fold (0.78 log units) below the measured number; measured number above the stated range.
By their numbers in this assay, from the lowest: compound 3; then compounds 2, 4 and 1 (each within the scatter of the next).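

In this assay, cyano in place of methyl on an aromatic carbon, para to a large group, gives a 15-fold higher number from compound 3 to compound 4 (1.18 log units; beyond the scatter) and so counts as a large step. This is the first single-point change shown on the six-membered aromatic ring of carbon only, and it reveals that the choice of group at this position matters strongly, unlike the change on the aromatic nitrogen, which stayed within the scatter. No measurement at hand explains why this swap weakens binding so much.

From the compounds shown here alone, with only methyl and cyano compared here, it remains open whether a chlorine atom, a methoxy group or an amine at this position would behave more like methyl or more like cyano. Going by these compounds, it is also open whether the same step would appear with ethyl or cyclobutyl on the aromatic nitrogen.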